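The source may hold more compounds than are shown below. What is called first, only, known or untested is meant among the compounds shown, and "the series" means these compounds.

Measured compounds:
compound 1 `O=[N+]([O-])c1cc2c(OCCC3CCCCN3)c(-c3ccccc3Cl)c(O)nc2cc1Cl`, which in a functional assay on cells (Pituitary gland cell) for antagonist activity at Gonadotropin-releasing hormone receptor (Rattus norvegicus) (on this read-out higher numbers stand for weaker inhibition and lower numbers for stronger inhibition), gives 360 nM;
compound 2 `O=[N+]([O-])c1cc2c(OCCC3CCCCN3)c(-c3cccc(F)c3)c(O)nc2cc1Cl`, which in this assay gives 53 nM.

Compound 2 holds the lowest of the two numbers; its nearest neighbour is compound 1, and the step of a 6.8-fold lower number from compound 1 to compound 2 (0.83 log units; beyond the scatter) lies beyond the scatter. Compound 3 `O=[N+]([O-])c1cc2c(OCCC3CCCCN3)c(-c3ccc4ccccc4c3)c(O)nc2cc1Cl` carries the change (naphthalen-2-yl in place of 3-fluorophenyl on an aromatic carbon). For the measured compounds named here, the only measured step that bears on this position is the swap of one aryl group for another from compound 1 to compound 2, which was of modest size. That step concerned a different pair of aryl groups, so it tells only that this position is sensitive to the aryl group, not in which direction a naphthalen-2-yl group will move the number. For compound 3 the expected step is therefore a 1.7-fold higher number from compound 2 to compound 3 (0.23 log units; within the scatter). Compound 3 is estimated to give 90 nM in this assay, with a range from 20 nM to 400 nM.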

Compound 3, half-maximal inhibitory concentration: 53 nM
Compound 3: the middle estimate sits 1.7-fold (0.23 log units) above what was measured; the measured number falls inside the stated range.
By their numbers in this assay, from the lowest: compounds 2 and 3 (each within the scatter of the next); then compound 1.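

In this assay, the swap of 3-fluorophenyl for naphthalen-2-yl gives no change at the digits printed from compound 2 to compound 3 (within the scatter), so this position accepts a second six-membered aromatic ring of carbon only, and the loss of the fluorine, with no step beyond the scatter. The step of a 6.8-fold lower number from compound 1 to compound 3 (0.83 log units; beyond the scatter) is the same in size as a 6.8-fold lower number from compound 1 to compound 2 (0.83 log units; beyond the scatter), which sets the 2-chlorophenyl of compound 1 apart from both other aryl groups. No evidence is available to explain this difference.

The compounds shown leave open whether the higher number of compound 1 goes with the chlorine itself or with where it sits on the ring, a question that a 3-chlorophenyl group at this position would address. They also leave open how a pyridin-3-yl group, or a phenyl group carrying a carboxylic acid, would fare here.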